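Aryl ketone exchange in a cytotoxicity series

The compounds below may be only part of what the source reports. "The series", "measured", "known", "first", "only" and "open" are said of these compounds alone.

Measured so far:
- compound 1 `COc1ccc(C(=O)/C=C/c2cc(-c3cc(OC)c(OC)c(OC)c3)n[nH]2)cc1`: 95%
- compound 2 `COc1ccc(C(=O)/C=C/c2cc(-c3cc(OC)c(OC)c(OC)c3)n[nH]2)cc1OC`: 92%

In a functional assay on LOX IMVI cells (Homo sapiens) for cytotoxicity, read by sulforhodamine B assay, with a stated time of 48 h, tested at 0.01 uM (a higher number here means a weaker effect of the compound at the concentration tested, a lower number a stronger effect), compound 1 gives 95% and compound 2 gives 92%. Among the measured compounds shown here, the one measured step, a number 3 percentage points lower from compound 1 to compound 2 (within the scatter), involves a methoxy in place of hydrogen on an aromatic carbon and falls within the scatter, so compound 2 stands at a number indistinguishable from that of compound 1 in this assay; on two values no ordering can be read.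

Compound 3 `COc1cc(-c2cc(/C=C/C(=O)c3ccc(F)c(F)c3)[nH]n2)cc(OC)c1OC` is not yet measured. It differs from compound 2 by 3,4-difluorophenyl in place of 3,4-dimethoxyphenyl on a carbonyl carbon. For the measured compounds named here, no measured step bears on this exchange: the only step available, from compound 1 to compound 2, concerns a single methoxy and sits within the scatter. Both measured numbers in this assay are high, meaning little effect at this concentration, and nothing in the series shows a change on the carbonyl-bound ring moving the read-out beyond the scatter.

Compound 3 is therefore expected to give 90% in this assay, with a range of 75% to 100%, a step of a number 2 percentage points lower from compound 2 to compound 3 (within the scatter) that is expected to stay within the scatter.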

Compound 3, a percentage reported as activity, at one concentration (the size of the read-out at that concentration, not a potency): 93%
Estimate against measurement, compound 3: 3 percentage points below; measured number inside the range.
By their numbers in this assay, from the lowest: compounds 2, 3 and 1 (each within the scatter of the next).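

In this assay the group on the carbonyl carbon is now exchanged as a whole ring: 3,4-difluorophenyl in place of 3,4-dimethoxyphenyl gives a number 1 percentage points higher from compound 2 to compound 3 (within the scatter) and 3,4-difluorophenyl in place of 4-methoxyphenyl gives a number 2 percentage points lower from compound 1 to compound 3 (within the scatter) as the second reading at this position. Where the earlier compounds showed only the addition of one methoxy on this ring, the read-out now also stays within the scatter when all of the ring's methoxy groups give way to fluorine, so three aryl groups on this carbonyl carbon cannot be told apart at this concentration. No measurement is at hand that would account for this flat outcome.

All three compounds sit at high numbers at the one concentration shown, so any difference among these aryl groups that would appear only at other concentrations stays hidden. On these data alone, whether an amine or a carboxylic acid on this ring, or a longer alkyl chain in place of the ring, would move the read-out beyond the scatter remains open.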